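The source may report more compounds than this note shows. Statements on the series, on what has been measured and on what is new or still open speak of the compounds shown alone.

Measured compounds in a functional assay on A549 cells (Homo sapiens) for antiproliferative activity, read by MTT assay, with a stated time of 48 h; on this read-out higher numbers stand for weaker inhibition and lower numbers for stronger inhibition:

Compound 1 `Cc1ccccc1-n1nncc1CN1C(=O)C2(C(C#N)=C(N)Oc3c2c2nc4ccccc4nc2c2ccccc32)c2ccccc21`: > 50000 nM
Compound 2 `COc1ccc(-n2nncc2CN2C(=O)C3(C(C#N)=C(N)Oc4c3c3nc5ccccc5nc3c3ccccc43)c3ccccc32)cc1`: > 50000 nM

Compound 2 stands at a limit of this assay, since its value of > 50000 nM is a ceiling the measurement reached rather than a number. The same holds for compound 1, whose value is also a limit. For the measured compounds named here, the only measured step, a step that the two limits leave unreadable from compound 1 to compound 2, cannot be read in size or direction, as the limit of > 50000 nM in this assay, at which 2 of the 2 values shown sit, shows both values resting at the same ceiling.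

Compound 3 `N#CC1=C(N)Oc2c(c3nc4ccccc4nc3c3ccccc23)C12C(=O)N(Cc1cnnn1-c1cccc(S(N)(=O)=O)c1)c1ccccc12` differs from compound 2 by one change: 3-sulfamoylphenyl in place of 4-methoxyphenyl on an aromatic nitrogen.

Going by the values given here, no measured step gives a readable size, so there is no basis for expecting a change in this assay beyond the scatter. Compound 3 is therefore estimated to give 60000 nM, with a range from 20000 nM to 200000 nM, most likely again as a limit. The step that the limit leaves unreadable from compound 2 to compound 3 is accordingly expected to be negligible.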

Compound 3, half-maximal inhibitory concentration: 44200 nM
Compound 3: middle estimate off by 1.4-fold (0.13 log units), on the high side; the range from low to high includes it.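

In this assay, for the compounds shown here, compound 3 is the first compound here to give a number rather than a limit, so a substituted phenyl on this aromatic nitrogen can bring the reading within the measurable range. Against the two limits, the result is an at least 1.1-fold lower number from compound 2 to compound 3 (0.05 log units; that floor lies within the scatter) and an at least 1.1-fold lower number from compound 1 to compound 3 (0.05 log units; that floor lies within the scatter); these are only floors, so they do not establish a change beyond the scatter. The other two compounds still give no number: the limit of > 50000 nM in this assay, at which 2 of the 3 values shown sit.

Going by these compounds, it remains open how far compound 3 truly lies from compound 1 and compound 2. On these data alone, it is also open whether a phenyl group carrying an amine or a carboxylic acid on this aromatic nitrogen would give a number in this assay, as 3-sulfamoylphenyl does.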